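The source may hold more compounds than are shown below. What is called first, only, known or untested is meant among the compounds shown, and "the series" means these compounds.

Working notes on the series. Compound 1 `CS(=O)(=O)Nc1ccc([N+](=O)[O-])cc1OCc1ccc([N+](=O)[O-])cc1` is the reference; in an assay on SK-BR-3 cells for inhibition of Aromatase (Homo sapiens) (a higher number here means a weaker inhibitor, a lower number a stronger inhibitor), compound 1 gives 400 nM. Compound 2 `Cc1ccc(COc2cc([N+](=O)[O-])ccc2NS(C)(=O)=O)cc1` carries methyl in place of nitro on an aromatic carbon; in this assay compound 2 gives 1750 nM, and the step of a 4.4-fold higher number from compound 1 to compound 2 (0.64 log units; beyond the scatter) is the only one of this kind measured so far. Compound 3 `O=[N+]([O-])c1ccc(S(=O)(=O)Nc2ccc([N+](=O)[O-])cc2OCc2ccccc2)cc1` has a different core; how it differs from the core of compound 1 is not broken down here. In this assay compound 3 gives 2170 nM. Compound 4 `Cc1ccc(S(=O)(=O)Nc2ccc([N+](=O)[O-])cc2OCc2ccccc2)cc1` is not yet measured; it differs from compound 3 by methyl in place of nitro on an aromatic carbon, the same change as between compound 1 and compound 2, at the same kind of place. The expectation for compound 4 in this assay rests on a single precedent, the step of a 4.4-fold higher number from compound 1 to compound 2 (0.64 log units; beyond the scatter), made on another core. On that basis the step of a 3.2-fold higher number from compound 3 to compound 4 (0.51 log units; beyond the scatter) is expected, giving an estimated value for compound 4 of 7000 nM, with 2500 nM and 20000 nM as the expected range.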

Compound 4, half-maximal inhibitory concentration: 17400 nM
Compound 4: the middle estimate sits 2.5-fold (0.40 log units) below what was measured; low and high end bracket the measured number.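

In this assay, methyl in place of nitro again gives a weaker inhibitor, with an 8.0-fold higher number from compound 3 to compound 4 (0.90 log units; beyond the scatter). The two steps run the same way and do not separate in size: the same change on two cores in this assay, a 4.4-fold higher number (0.64 log units; beyond the scatter) from compound 1 to compound 2 and an 8.0-fold higher number (0.90 log units; beyond the scatter) from compound 3 to compound 4, 1.8-fold (0.26 log units) apart, within the scatter of two such steps. The change therefore carries over in direction and, within the scatter, in size between the core of compound 1 and the core of compound 3, but two cores do not show that it will hold on any other core, and these steps do not explain the difference.

From the compounds shown here alone, only methyl is set against nitro here, so it remains open whether another group in its place, such as a nitrile, an amine or a carboxylic acid, would match nitro in this assay.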